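Swapping the aryl for cyclohexyl on the thioether chain

This account rests on a few compounds, and the source may have more. Where it says the series, first, only, none or still open, it means among the compounds named here.

Measured compounds in an ADME assay on GES1 cells (Homo sapiens) for inhibition, read by MTT assay, with a stated time of 72 h; on this read-out lower numbers stand for stronger inhibition and higher numbers for weaker inhibition:
- Compound 1 `Cc1cc(Nc2cc(-c3ccccc3)[nH]n2)n2nc(SCc3csc4ccccc34)nc2n1` gives 29200 nM.
- Compound 2 `Cc1cc(Nc2cc(-c3ccccc3)[nH]n2)n2nc(SCc3cccc(Br)c3)nc2n1` reaches only the assay limit, > 50000 nM, which is not a number.
- Compound 3 `Cc1cc(Nc2cc(-c3ccccc3)[nH]n2)n2nc(SCc3ccc(F)cc3)nc2n1` gives 35500 nM.

Compound 3 holds the highest of the two numbers available, with compound 1 nearest at a 1.2-fold higher number from compound 1 to compound 3 (0.08 log units; within the scatter), a gap inside the scatter. Compound 3 and compound 2 differ by an at least 1.4-fold lower number from compound 2 to compound 3 (0.14 log units; that floor lies within the scatter), and compound 1 and compound 2 by an at least 1.7-fold higher number from compound 1 to compound 2 (0.23 log units; that floor lies within the scatter); none of these steps rises above the scatter, and one of them rests on the limit described in the limit of > 50000 nM in this assay, at which 1 of the 3 values shown sits.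

Compound 4 `Cc1cc(Nc2cc(-c3ccccc3)[nH]n2)n2nc(SCC3CCCCC3)nc2n1` is the next compound. Its change from compound 3: cyclohexyl in place of 4-fluorophenyl on a saturated chain carbon bound to a sulfur. For the measured compounds named here, no measured step involves a cyclohexyl at this place, so the only guide is that three varied groups on the saturated chain carbon bound to a sulfur all left the read-out within scatter. Compound 4 is therefore expected to show no step beyond the scatter, an estimated 1.0-fold higher number from compound 3 to compound 4 (0.01 log units; within the scatter).

Compound 4 is estimated at 36000 nM, within 15000 nM to 80000 nM.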

Compound 4, half-maximal inhibitory concentration: > 50000 nM
Compound 4: only a limit was reported; the forecaster's own chance of this, stated with the estimate: 35%; middle value at least 1.3-fold (0.14 log units) away from the limit.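

Compound 4 reaches > 50000 nM in this assay as a limit of the assay, not a number. Its cyclohexyl is the only non-aromatic ring shown on the saturated chain carbon bound to a sulfur, and it gives an at least 1.4-fold higher number from compound 3 to compound 4 (0.14 log units; that floor lies within the scatter) and an at least 1.7-fold higher number from compound 1 to compound 4 (0.23 log units; that floor lies within the scatter) as the two readable steps, so nothing here shows that an aromatic ring at this place changes the read-out beyond the scatter. The step from compound 2 to compound 4 cannot be read, because both compounds stand at the same limit: the limit of > 50000 nM in this assay, at which 2 of the 4 values shown sit.

On these data alone, how large the two readable steps really are stays open. Also open, as far as these compounds go, is what an amine, a carboxylic acid or a longer chain at this place would do to the read-out.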